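Changing the amide aryl group and cell toxicity

A few compounds are considered here, and "the series" means these few. Any claim that something is new, unique, unknown or untested is made for them only; others in the source may bear on it.

Compound 1, `COc1ccc2nc(C)cc(OCC(=O)Nc3cc(C)ccc3OC)c2c1`: in a toxicity assay on HepG2 cells (Homo sapiens) for inhibition, read by CellTiter-Glo, with a stated time of 48 h (a higher number here means a weaker inhibitor, a lower number a stronger inhibitor), compound 1 gives > 100000 nM, which is a limit of the assay.
Compound 2, `COc1ccc2nc(C)cc(OCC(=O)Nc3cc(F)cc(F)c3)c2c1`: in this assay compound 2 gives > 100000 nM, again a limit.
Compound 3, `COc1ccc2nc(C)cc(OCC(=O)Nc3ccccn3)c2c1`: in this assay compound 3 gives > 100000 nM, also a limit.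

Compound 3 thus stands where every measured compound stands, at the limit of > 100000 nM in this assay, at which 3 of the 3 values shown sit; no number separates it from the others. Compound 4, `COc1ccc2nc(C)cc(OCC(=O)Nc3cc(C)nc(C)n3)c2c1`, differs from compound 3 by 2,6-dimethylpyrimidin-4-yl in place of pyridin-2-yl on an amide-type nitrogen. The measured steps that bear on this change, a step that the two limits leave unreadable from compound 1 to compound 3, a step that the two limits leave unreadable from compound 2 to compound 3 and a step that the two limits leave unreadable from compound 1 to compound 2, are unreadable in size because each begins and ends at the limit of > 100000 nM in this assay, at which 3 of the 3 values shown sit. Swapping the group on the amide-type nitrogen has left no readable mark so far, so for compound 4 the expected step that the limit leaves unreadable from compound 3 to compound 4 is none beyond the scatter, most likely again a limit. Compound 4 is expected to give about 150000 nM in this assay, in the range 50000 nM to 500000 nM.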

Compound 4, half-maximal inhibitory concentration: > 100000 nM
Compound 4 was reported as a limit; the forecaster's own chance of this, stated with the estimate: 85%; the middle value lies beyond the limit too.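

The steps to compound 4 from compound 1, compound 2 and compound 3 cannot be read, because all four compounds sit at the same limit: the limit of > 100000 nM in this assay, at which 4 of the 4 values shown sit.

The compounds shown leave open whether any group on the amide-type nitrogen changes the result in this assay, since none gives an actual number.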